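This account rests on a few compounds, and the source may have more. Where it says the series, first, only, none or still open, it means among the compounds named here.

Compound 3 `CCCC(=O)c1ccc(OCCCCOc2ccc(C(=O)O)cc2C)c(C)c1O` gives 40.5% in an assay on HEK293 cells for positive allosteric modulation of metabotropic glutamate receptor 3 (Rattus norvegicus), read by thallium flux, with a stated time of 2.5 min; a higher number here means a larger maximal response, a lower number a smaller maximal response. Among the three measured compounds it stands second highest. Its nearest neighbour is compound 2 `Cc1cc(C(=O)O)ccc1OCCCCOc1ccc(C(=O)CC(C)C)c(O)c1C`, which gives 42.1%, a difference that lies within the usual scatter, so the two cannot be ranked. Compound 1 `COc1cc(C(=O)O)ccc1OCCCCOc1ccc(C(=O)C(C)C)c(O)c1C` gives 25.6%, and this gap to compound 3 lies beyond the scatter.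

The step to compound 4 `Cc1cc(C(=O)O)ccc1OCCCCOc1ccc(C(=O)C(C)C)c(O)c1C` is isopropyl in place of propyl on a carbonyl carbon. Among the compounds with values here, one measured step touches the same part of the molecule: a number 1.6 percentage points lower from compound 2 to compound 3 (within the scatter), and this change of the chain on the carbonyl carbon left the largest response essentially where it was. Compound 1 also carries an isopropylcarbonyl group, but it differs from compound 4 in a second place as well, so its lower standing cannot be attributed to that group alone.

Within the data shown here, on the strength of the single neighbouring step, no shift beyond the scatter is expected, and compound 4 is estimated at 38%, with a range from 26% to 50%. That estimate corresponds to an expected step of a number 2.5 percentage points lower from compound 3 to compound 4 (within the scatter).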

Compound 4, largest response reached (reported as percent of maximum), in percent of the reference or control that the assay uses: 25.2%
Estimate against measurement, compound 4: 12.8 percentage points above; measured number outside the range, below it.
By their numbers in this assay, from the lowest: compounds 4 and 1 (each within the scatter of the next); then compounds 3 and 2 (each within the scatter of the next).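

On the carbonyl carbon, the exact shape of the chain matters in this assay: isopropyl in place of propyl gives a number 15.3 percentage points lower from compound 3 to compound 4 (beyond the scatter) and isopropyl in place of isobutyl gives a number 16.9 percentage points lower from compound 2 to compound 4 (beyond the scatter), although propyl and isobutyl themselves could not be told apart. On an aromatic carbon, methyl in place of methoxy gives a number 0.4 percentage points lower from compound 1 to compound 4 (within the scatter), so this swap leaves the largest response unchanged within the scatter, and the methoxy group does not set compound 1 apart from compound 4. Nothing measured here explains why the isopropyl chain goes with the smaller response.

On these data alone, whether a tert-butyl or cyclopropyl group on the carbonyl carbon would behave like isopropyl remains open. So does whether the isopropyl effect would persist with a longer chain linking the two aromatic parts.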